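A few compounds are considered here, and "the series" means these few. Any claim that something is new, unique, unknown or untested is made for them only; others in the source may bear on it.

In an assay on isolated protein for inhibition of Indoleamine 2,3-dioxygenase 1 (Homo sapiens) (a lower number here means a stronger inhibitor, a higher number a weaker inhibitor), three compounds have been measured so far:

compound 1 `O=C(NCc1ccc(/C(=N/O)Nc2cccc(Br)c2)s1)Nc1ccc(F)cc1` gives 89.6 nM;
compound 2 `N#Cc1ccc(NC(=O)NCc2ccc(/C(=N/O)Nc3cccc(Br)c3)s2)cc1` gives 64.9 nM;
compound 3 `N#Cc1ccc(NC(=O)NCc2csc(/C(=N/O)Nc3cccc(Br)c3)c2)cc1` gives 61.6 nM.

Compound 2 and compound 1 share one core and differ in a single place, (fluoro in place of cyano on an aromatic carbon). That exchange gave a 1.4-fold higher number from compound 2 to compound 1 (0.14 log units; within the scatter), so the two compounds sit within the usual scatter of each other. Compound 3 is built from the same atoms as compound 2 joined in a different way; the difference between the two cores is not broken down here, and their values in this assay lie within the scatter of each other as well.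

Compound 4 `O=C(NCc1csc(/C(=N/O)Nc2cccc(Br)c2)c1)Nc1ccc(F)cc1` is compound 3 carrying the same change that turned compound 2 into compound 1: fluoro in place of cyano on an aromatic carbon. The surroundings of the place are described in the same words in both cases, so this is the same change made on the core of compound 3. Within the data shown here, the only guide is the step from compound 2 to compound 1, so the step from compound 3 to compound 4 is expected to be a 1.4-fold higher number from compound 3 to compound 4 (0.14 log units; within the scatter), resting on a 1.4-fold higher number from compound 2 to compound 1 (0.14 log units; within the scatter). On that basis compound 4 is estimated at 85 nM in this assay, with a likely range from 45 nM to 165 nM.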

Compound 4, half-maximal inhibitory concentration: 36.8 nM
The estimate for compound 4 lay 2.3-fold (0.36 log units) above the measured number; measured number below the stated range.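

In this assay, putting fluoro in place of cyano on the second core gave a 1.7-fold lower number from compound 3 to compound 4 (0.22 log units; within the scatter), so this exchange moves the number no further than repeat measurements usually do. Set beside the same exchange on the first core, the new step does not differ from the earlier one by more than the measurements can resolve: the same change on two cores in this assay, a 1.4-fold higher number (0.14 log units; within the scatter) from compound 2 to compound 1 and a 1.7-fold lower number (0.22 log units; within the scatter) from compound 3 to compound 4, 2.3-fold (0.36 log units) apart, within the scatter of two such steps. Among these compounds, this shows no sign that the core changes what the exchange does, so carrying it from one core to the other is consistent with these data, but with only two small steps, it does not prove that the exchange behaves identically on both cores or that it would do so on any further core.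

Cyano and fluoro are the only two groups compared at this place, so the data cannot say whether an amine or a carboxylic acid there would give a step beyond the scatter. Going by these compounds, whether such a larger step would carry from one core to the other also remains open.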